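Swapping the styryl arm for a trimethoxyphenyl group

The compounds below may be only part of what the source reports. "The series", "measured", "known", "first", "only" and "open" are said of these compounds alone.

Compound 3 `Cc1cc(O)c(C2=NN(c3ccc(S(N)(=O)=O)cc3)C(/C=C/c3ccccc3)C2)cc1Cl` belongs to a small set sharing one core and tested in a functional assay on RPMI-8226 cells (Homo sapiens) for antiproliferative activity, with a stated time of 48 h (on this read-out higher numbers stand for weaker inhibition of growth and lower numbers for stronger inhibition of growth), where compound 3 gives 20600 nM. Its neighbours are compound 1 `Cc1cc(O)c(C2=NN(c3ccc(S(N)(=O)=O)cc3)C(c3ccccc3O)C2)cc1Cl` with 15000 nM and compound 2 `Cc1cc(O)c(C2=NN(c3ccc(S(N)(=O)=O)cc3)C(c3ccccc3Cl)C2)cc1Cl` with 8350 nM. The change a 1.4-fold higher number from compound 1 to compound 3 (0.14 log units; within the scatter) lies within the scatter, whereas a 2.5-fold higher number from compound 2 to compound 3 (0.39 log units; beyond the scatter) is a modest step beyond it. Compound 4 `COc1ccc(C2CC(c3cc(Cl)c(C)cc3O)=NN2c2ccc(S(N)(=O)=O)cc2)c(OC)c1OC` differs from compound 3 by 2,3,4-trimethoxyphenyl in place of 2-phenylethenyl on a saturated ring carbon. The earlier changes at the same saturated ring carbon all stayed within a narrow band, so the new group is expected to shift the number only a little, perhaps slightly downward, and no step beyond the scatter is expected in this assay as a 1.7-fold lower number from compound 3 to compound 4 (0.23 log units; within the scatter). Compound 4 is therefore estimated at 12000 nM, with a range from 4500 nM to 35000 nM.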

Compound 4, concentration for total growth inhibition: 14800 nM
Beside the measured number, compound 4's estimate is 1.2-fold (0.09 log units) below it; low and high end bracket the measured number.
By their numbers in this assay, from the lowest: compounds 2, 4, 1 and 3 (each within the scatter of the next, the first and the last beyond it).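

In this assay, 2,3,4-trimethoxyphenyl, with 12 heavy atoms and 3 hydrogen-bond acceptors, replaces each earlier group on the saturated ring carbon without a step beyond the scatter: a 1.4-fold lower number from compound 3 to compound 4 (0.14 log units; within the scatter), a 1.8-fold higher number from compound 2 to compound 4 (0.25 log units; within the scatter) and a 1.0-fold lower number from compound 1 to compound 4 (0.01 log units; within the scatter). Adding these oxygen-bearing substituents therefore opens no new gap at this position, and the only step beyond the scatter remains the one between compound 2 and compound 3. Nothing available explains why the number moves so little here. On these data alone, whether an amine or a carboxylic acid at this position would move the number out of this narrow band remains open.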